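The source may report more compounds than this note shows. Statements on the series, on what has been measured and on what is new or still open speak of the compounds shown alone.

Three analogues on one shared core have been measured in a functional assay on isolated protein for inhibition of Glucose-dependent insulinotropic receptor (Homo sapiens), read by HTRF and cAMP accumulation; a higher number here means that more compound is needed for the effect, a lower number that less compound is needed. Compound 1 `Cc1nc(S(C)(=O)=O)ccc1Oc1ncnc(OC2CCN(C(=O)OC(C)(C)C(F)(F)F)CC2)c1F` gives 6.53 nM. Compound 2 `Cc1nc(S(C)(=O)=O)ccc1Oc1ncnc(OC2CCN(C(=O)OC(C)(C)CF)CC2)c1F` gives 19.9 nM. Compound 3 `Cc1nc(S(C)(=O)=O)ccc1Oc1ncnc(OC2CCN(C(=O)OC(C)F)CC2)c1F` gives 65.5 nM, the highest of the three numbers; its nearest neighbour is compound 2 and its furthest compound 1. The steps among them are a 3.0-fold higher number from compound 1 to compound 2 (0.48 log units; beyond the scatter), a 10-fold higher number from compound 1 to compound 3 (1.00 log units; beyond the scatter) and a 3.3-fold higher number from compound 2 to compound 3 (0.52 log units; beyond the scatter), each beyond the scatter, and each a change of the group sitting on an oxygen next to a carbonyl group.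

Compound 4 `Cc1nc(S(C)(=O)=O)ccc1Oc1ncnc(OC2CCN(C(=O)c3nc(C(C)(C)F)no3)CC2)c1F` goes in a different direction: a group of 9 heavy atoms (5 carbon, 2 nitrogen, 1 oxygen, 1 fluorine; one five-membered aromatic ring with 3 hetero atoms) in place of a group of 4 heavy atoms (2 carbon, 1 oxygen, 1 fluorine; no ring), on a carbonyl carbon. Within the data shown here, no measured step covers a change of this kind. What the measured steps do show is that the group attached to the carbonyl carbon moves the number across the whole spread of the series, the more heavily fluorinated and more branched groups giving the lower numbers. Compound 4 again carries a branched fluorinated group, now carried on a five-membered aromatic ring, so the expected step is a 4.4-fold lower number from compound 3 to compound 4 (0.64 log units; beyond the scatter), a move back towards the lower numbers rather than further upward, with wide uncertainty given the lack of a direct precedent. Compound 4 is therefore estimated at 15 nM, with a range from 4 nM to 60 nM.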

Compound 4, half-maximal effective concentration: 43.4 nM
Beside the measured number, compound 4's estimate is 2.9-fold (0.46 log units) below it; the range from low to high includes it.
By their numbers in this assay, from the lowest: compound 1; then compound 2; then compounds 4 and 3 (each within the scatter of the next).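

In this assay, replacing the group of 4 heavy atoms on the carbonyl carbon with the group of 9 heavy atoms containing the five-membered aromatic ring gives a 1.5-fold lower number from compound 3 to compound 4 (0.18 log units; within the scatter), so this much larger change leaves compound 4 unseparated from compound 3. The other two comparisons, a 2.2-fold higher number from compound 2 to compound 4 (0.34 log units; beyond the scatter) and a 6.6-fold higher number from compound 1 to compound 4 (0.82 log units; beyond the scatter), show that the ring-bearing group does not reach the numbers given by the two branched groups on oxygen, and compound 4 therefore goes against the trend across compounds 1, 2 and 3, where a larger group went with a lower number. No supporting data bear on this result.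

The compounds shown leave open how much of the outcome belongs to the five-membered aromatic ring and how much to the fluorinated group it carries, since both differ from the earlier groups at once. A trifluoromethyl group on the same ring, or a 1,1-dimethylethyl group without fluorine on the oxygen of the carbamate, would help to separate these contributions.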